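Solubility notes on the aminoquinoline-chain series

The compounds below may be only part of what the source reports. "The series", "measured", "known", "first", "only" and "open" are said of these compounds alone.

Measured so far:
compound 1 `COc1cccc(CNCCCNc2ccnc3cc(-c4ccc(C(F)(F)F)cc4)ccc23)c1O`, 32000 nM
compound 2 `COc1ccc(F)cc1CNCCCNc1ccnc2cc(CCc3ccccc3)ccc12`, 4200 nM
compound 3 `FC(F)(F)c1ccc(-c2ccc3c(NCCCNCc4ccco4)ccnc3c2)cc1`, 32000 nM

In a physicochemical assay for solubility, with a stated time of 18 h, at pH 7.4 (on this read-out higher numbers stand for higher solubility and lower numbers for lower solubility), compound 3 stands level with compound 1, and the two together give the highest numbers of the three; compound 2 lies furthest off, with a lower value. Going by the values given here, the only single-point step measured is no change at the digits printed from compound 1 to compound 3 (within the scatter), which concerns the chain end and not the position that now changes.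

Compound 4 `N#Cc1ccc(Cc2ccc3c(NCCCNCc4ccco4)ccnc3c2)cc1` differs from compound 3 in one place: 4-cyanobenzyl in place of 4-(trifluoromethyl)phenyl on an aromatic carbon. Among the compounds with values here, no measured step touches this position directly. Within the data shown here, compound 2 carries a different group there, but it differs from compound 3 in a second place as well, so its value shows only that another group at that position went with a lower number, not by how much this exchange would move it.

Without a step that bears on the change, the expected step is a 1.1-fold lower number from compound 3 to compound 4 (0.03 log units; within the scatter), no movement beyond the scatter. Compound 4 is therefore estimated at 30000 nM, within 10000 nM to 90000 nM.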

Compound 4, solubility: 4200 nM
Compound 4: the middle estimate sits 7.1-fold (0.85 log units) above what was measured; measured number outside the range, below it.
By their numbers in this assay, from the lowest: compounds 2 and 4 (each within the scatter of the next); then compounds 1 and 3 (each within the scatter of the next).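

In this assay, 4-cyanobenzyl in place of 4-(trifluoromethyl)phenyl on the aromatic carbon gives a 7.6-fold lower number from compound 3 to compound 4 (0.88 log units; beyond the scatter). Going by these compounds alone, this is the only single-point step at this position, and it shows that the position can move the number beyond the scatter. The single-point step at the chain end, no change at the digits printed from compound 1 to compound 3 (within the scatter), showed no such movement, and nothing measured here accounts for the drop.

The exchange alters two things at once, the saturated carbon of the benzyl group and the nitrile in place of trifluoromethyl, and the compounds shown do not separate them; 4-cyanophenyl or 4-(trifluoromethyl)benzyl at this position would do so. Also open, on these data alone, is whether the step holds with the 2-hydroxy-3-methoxyphenyl chain end of compound 1, and what an amine or a carboxylic acid on the ring would give.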